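Series notes: the step from compound 1 to compound 4

This account rests on a few compounds, and the source may have more. Where it says the series, first, only, none or still open, it means among the compounds named here.

Among the measured compounds shown here, in a functional assay on K562 cells (Homo sapiens) for antiproliferative activity, read by MTT assay, with a stated time of 24 h (a lower number here means a stronger inhibitor, a higher number a weaker inhibitor), compound 1 (`COC(=O)c1scc(-c2ccc(NC(=O)c3ccc(F)c(Cl)n3)cc2)c1OC`) gives 8250 nM, the lowest number so far, though compound 2 (`COC(=O)c1scc(-c2ccc(NC(=O)c3ccc(C(F)(F)F)cc3Br)cc2)c1OC`), at 9250 nM, lies within the scatter of it. Compound 3 (`COC(=O)c1scc(-c2ccc(NC(=O)c3cccc(OC(F)(F)F)c3)cc2)c1OC`), at 18300 nM, lies beyond the scatter of compound 1. Compound 4 (`COC(=O)c1scc(-c2ccc(NC(=O)c3ccc(OC)nc3)cc2)c1OC`) carries 6-methoxypyridin-3-yl in place of 6-chloro-5-fluoropyridin-2-yl on a carbonyl carbon. For the measured compounds named here, no measured pair isolates a single change, so the expectation rests only on the narrow range of values from compound 1 at 8250 nM to compound 3 at 18300 nM. A step within the scatter, towards a higher number, is expected, estimated as a 1.6-fold higher number from compound 1 to compound 4 (0.20 log units; within the scatter). Compound 4 is expected at 13000 nM, with an estimated range of 6000 nM to 35000 nM.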

Compound 4, half-maximal inhibitory concentration: 18300 nM
Estimate against measurement, compound 4: 1.4-fold (0.15 log units) below; the range from low to high includes it.
By their numbers in this assay, from the lowest: compounds 1, 2, 3 and 4 (each within the scatter of the next, the first and the last beyond it).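

In this assay, the place on the carbonyl carbon now has its first single-change reading: a 2.2-fold higher number from compound 1 to compound 4 (0.35 log units; beyond the scatter), a modest step. The exchange of one pyridinyl group for another therefore registers at this position, with 6-chloro-5-fluoropyridin-2-yl giving the lower number. No measurement available here bears on the cause of this step.

The compounds shown do not separate the contributions of the chlorine, the fluorine, the methoxy group and the point of attachment. As far as these compounds go, how a pyridinyl group carrying an amine or a carboxylic acid would read here also remains open.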